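Carboxy on the distal phenyl of compound 2

The source may report more compounds than this note shows. Statements on the series, on what has been measured and on what is new or still open speak of the compounds shown alone.

Compound 2 `CC(Oc1ccc(Oc2ccc(C(F)(F)F)cc2)cc1)C(=O)Cn1nnc(-c2ccccc2)n1` gives 160 nM in an assay on microsomes from brain for inhibition of Fatty-acid amide hydrolase 1 (Rattus norvegicus), read by fluorescence and HPLC, with a stated time of 60 min (a higher number here means a weaker inhibitor, a lower number a stronger inhibitor), the higher of the two numbers measured, while compound 1 `CCCCCCCCc1ccc(OC(C)C(=O)Cn2nnc(-c3ccccc3)n2)cc1` gives 24 nM. Within the data shown here, the only measured step, a 6.7-fold higher number from compound 1 to compound 2 (0.82 log units; beyond the scatter), concerns the other end of the molecule and does not bear on the change to compound 3 `CC(Oc1ccc(Oc2ccc(C(F)(F)F)cc2)cc1)C(=O)Cn1nnc(-c2ccc(C(=O)O)cc2)n1`, which is carboxy in place of hydrogen on an aromatic carbon. Among the measured compounds shown here, no measured step therefore guides the expectation for compound 3, and the estimate is a widely bracketed, modest weakening, a 2.5-fold higher number from compound 2 to compound 3 (0.40 log units; beyond the scatter), so that compound 3 is expected near 400 nM, within 100 nM to 2000 nM.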

Compound 3, half-maximal inhibitory concentration: 160 nM
For compound 3 the middle estimate is 2.5-fold (0.40 log units) above the measured one; measured number inside the range.
By their numbers in this assay, from the lowest: compound 1; then compounds 2 and 3 (each within the scatter of the next).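

In this assay, the change from phenyl to 4-carboxyphenyl gives no change at the digits printed from compound 2 to compound 3 (within the scatter). Among these compounds, this is the first reading at this end of the molecule, and it shows that this position, on the aromatic ring para to a large group, can carry carboxy with no measurable loss against the hydrogen of compound 2. Nothing available explains this result. The compounds shown leave open whether an amine, a nitrile or a methyl ester would fare alike here, and whether carboxy would behave the same alongside the octyl group of compound 1.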